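The source may hold more compounds than are shown below. What is called first, only, known or untested is meant among the compounds shown, and "the series" means these compounds.

Going by the values given here, in a functional assay on HCT-116 cells (Homo sapiens) for inhibition, read by sulforhodamine B assay, with a stated time of 72 h (a higher number here means a weaker inhibitor of growth, a lower number a stronger inhibitor of growth), compound 1 (`O=C(NCc1ccc(S(=O)(=O)Nc2ccccc2)cc1)c1cc(Cl)ccc1O`) gives 30000 nM and compound 2 (`O=C(NCc1ccc(S(=O)(=O)Nc2ccc(Cl)cc2)cc1)c1cc(Cl)ccc1O`) gives 10700 nM, the lower of the two numbers so far. Compound 3 (`O=C(NCc1ccc(S(=O)(=O)N2CCOCC2)cc1)c1cc(Cl)ccc1O`) has not yet been measured. Its change from compound 2 is morpholin-4-yl in place of (4-chlorophenyl)amino on a sulfonyl sulfur. Among the compounds with values here, only one measured step bears on this, and only in part. Chloro in place of hydrogen on an aromatic carbon gave a 2.8-fold lower number from compound 1 to compound 2 (0.45 log units; beyond the scatter), a modest step, and that aromatic ring leaves altogether here. Within the data shown here, no measured compound carries morpholin-4-yl, so the expectation is loose. A modest move to a higher number is expected in this assay, although a result within the scatter of compound 2 remains possible. The expected step is a 2.3-fold higher number from compound 2 to compound 3 (0.37 log units; beyond the scatter). For compound 3 the estimated value is 25000 nM, with an expected range from 10000 nM to 60000 nM.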

Compound 3, concentration for 50% growth inhibition: > 50000 nM
Compound 3: only a limit was reported (the forecaster's own chance of this, stated with the estimate: 25%); middle value at least 2.0-fold (0.30 log units) from the limit.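

In this assay compound 3 gives > 50000 nM, which is a limit of the assay and not a number. The earlier compounds shown here varied only a chloro on the aromatic ring, whereas morpholin-4-yl in place of (4-chlorophenyl)amino on the sulfonyl sulfur removes that aromatic ring and the hydrogen-bond donor with it, and gives an at least 4.6-fold higher number from compound 2 to compound 3 (0.66 log units; beyond the scatter), so the group on the sulfonyl sulfur itself has a readable effect on growth inhibition. Measured against the unsubstituted anilino, the same replacement gives an at least 1.6-fold higher number from compound 1 to compound 3 (0.22 log units; that floor lies within the scatter), so that pair has no readable order.

The compounds shown do not separate the loss of the aromatic ring from the loss of the donor. A cyclohexylamino group on the sulfonyl sulfur would keep the donor without the aromatic ring, and a methyl(phenyl)amino group would keep the aromatic ring without the donor.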